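The source may hold more compounds than are shown below. What is called first, only, known or untested is meant among the compounds shown, and "the series" means these compounds.

Of the compounds shown here, three built on one shared core have been measured in a functional assay on HT-29 cells (Homo sapiens) for antiproliferative activity, read by sulforhodamine B assay, with a stated time of 72 h; on this read-out higher numbers stand for weaker inhibition and lower numbers for stronger inhibition. Compound 1 `S=C(N/N=C/c1ccc2ccccc2n1)Nc1ccc(Br)cc1` gives 54400 nM. Compound 2 `COc1cccc(NC(=S)N/N=C/c2ccc3ccccc3n2)c1` gives 82400 nM. Compound 3 `N#Cc1ccc(NC(=S)N/N=C/c2ccc3ccccc3n2)cc1` gives 15600 nM, the lowest of the three numbers; the steps of a 3.5-fold lower number from compound 1 to compound 3 (0.54 log units; beyond the scatter) and a 5.3-fold lower number from compound 2 to compound 3 (0.72 log units; beyond the scatter) are both beyond the scatter, so compound 3 stands as the strongest inhibitor of the three, while compounds 1 and 2 lie within the scatter of each other, as shown by a 1.5-fold higher number from compound 1 to compound 2 (0.18 log units; within the scatter).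

Compound 4 `Fc1ccccc1NC(=S)N/N=C/c1ccc2ccccc2n1` has not yet been measured. It differs from compound 3 in one place: 2-fluorophenyl in place of 4-cyanophenyl on an amide-type nitrogen. The two steps that bear on this change are the ones leading to compound 3, in which a cyano group appeared on the aryl group on the amide-type nitrogen and the number fell by a modest amount each time. Compound 4 loses that cyano group and carries instead a fluorine on the phenyl ring, much as compounds 1 and 2 carry a bromo or methoxy group, so the expected step is a 3.2-fold higher number from compound 3 to compound 4 (0.51 log units; beyond the scatter), back toward the numbers of compounds 1 and 2. Compound 4 is therefore estimated at 50000 nM, within a range of 15000 nM to 160000 nM.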

Compound 4, half-maximal inhibitory concentration: > 100000 nM
Compound 4 gave a limit, no number; the forecaster's own chance of this, stated with the estimate: 10%; middle value at least 2.0-fold (0.30 log units) away from the limit.
By their numbers in this assay, from the lowest: compound 3; then compounds 1 and 2 (each within the scatter of the next). At a limit, above all of these: compound 4.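

In this assay compound 4 gives > 100000 nM, which is a limit of the assay and not a number. Even so, one step can be read: an at least 6.4-fold higher number from compound 3 to compound 4 (0.80 log units; beyond the scatter). Going by these compounds alone, on this amide-type nitrogen, 2-fluorophenyl therefore gives weaker inhibition than 4-cyanophenyl, which extends the earlier finding that compound 3 stands apart, while the floors of the other two steps, an at least 1.2-fold higher number from compound 2 to compound 4 (0.08 log units; that floor lies within the scatter) and an at least 1.8-fold higher number from compound 1 to compound 4 (0.26 log units; that floor lies within the scatter), set no order among those compounds.

The compounds shown leave open whether the lower number of compound 3 belongs to the nitrile itself or would also appear with a carboxylic acid or an amine in its place. They also leave open how an unsubstituted phenyl group would compare on this nitrogen.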